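Shifting a Chlorine Around the Aryl Ether

This account rests on a few compounds, and the source may have more. Where it says the series, first, only, none or still open, it means among the compounds named here.

Measured so far:
- compound 1 `NC1=NC2(CCSCC2)N(OCCCOc2ccc(Cl)cc2)C(N)=N1`: 10 nM
- compound 2 `NC1=NC2(CCOCC2)N(OCCCOc2ccc(Cl)cc2Cl)C(N)=N1`: 880 nM
- compound 3 `CC(C)(C)c1ccc(OCCCON2C(N)=NC(N)=NC23CCSCC3)cc1`: 1 nM

These three compounds share a core and were tested in a functional assay on HCT-116 cells (Homo sapiens) for antiproliferative activity, read by MTT assay, with a stated time of 72 h; a lower number here means a stronger inhibitor, a higher number a weaker inhibitor. Compound 1 stands second highest of the three numbers; compound 3 sits closest, with a 10-fold lower number from compound 1 to compound 3 (1.00 log units; beyond the scatter), while compound 2 lies furthest, with a far higher number. Among the measured compounds shown here, compound 2 differs from compound 1 in more than one place, so its gap to compound 1 shows only that the two values differ, not what caused it.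

Compound 4 `NC1=NC2(CCSCC2)N(OCCCOc2ccccc2Cl)C(N)=N1` has not yet been measured. It differs from compound 1 as follows: 2-chlorophenyl in place of 4-chlorophenyl on an oxygen on a saturated carbon. For the measured compounds named here, none of the measured steps moves the chlorine around the ring; the only single-point step, a 10-fold lower number from compound 1 to compound 3 (1.00 log units; beyond the scatter), swaps one group for another on an aromatic carbon. The data therefore offer no direct guide to this change, and the expectation rests on compound 1 giving 10 nM together with the absence of any measured step of this kind. A somewhat higher number is expected for compound 4, as a 5.0-fold higher number from compound 1 to compound 4 (0.70 log units; beyond the scatter), with wide uncertainty. The estimate for compound 4 in this assay is 50 nM, with a range from 8 nM to 300 nM.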

Compound 4, half-maximal inhibitory concentration: 1 nM
Estimate against measurement, compound 4: 50-fold (1.70 log units) above; the whole stated range lies above it.
By their numbers in this assay, from the lowest: compounds 3 and 4 (each within the scatter of the next); then compound 1; then compound 2.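

In this assay, moving the chlorine on the aryl ether from 4-chlorophenyl to 2-chlorophenyl gives a 10-fold lower number from compound 1 to compound 4 (1.00 log units; beyond the scatter) and so shows that, at this place on the molecule, where the chlorine sits on the ring matters as well as which group is there. The earlier single-place step, a 10-fold lower number from compound 1 to compound 3 (1.00 log units; beyond the scatter), exchanged chloro for tert-butyl and so changed the group itself, whereas the new pair has the same atoms joined differently, and the group that leaves and the one that enters count the same heavy atoms. Nothing measured here explains why this shift in the chlorine changes the antiproliferative reading.

On these data alone, it remains open whether a fluorine, a methoxy group or an amine in place of this chlorine would give a similar number, and whether a longer chain linking the 2-chlorophenoxy group to the shared core would keep it. Compound 2 carries two chlorines on its ring but differs from compound 1 in more than one place, so it cannot show how a second chlorine acts on the ring of compound 4.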